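Chloro for Methyl on a Shared Amide Core

The source may hold more compounds than are shown below. What is called first, only, known or untested is meant among the compounds shown, and "the series" means these compounds.

Compound 1, `Cc1ccc(-c2ccc(C(=O)Nc3ccc(Oc4ccnc5[nH]ccc45)cc3)nc2)cc1`: in a functional assay on PC-3 cells (Homo sapiens) for cytotoxicity, read by MTT assay, with a stated time of 72 h (a lower number here means a stronger inhibitor, a higher number a weaker inhibitor), compound 1 gives > 10000 nM, which is a limit of the assay and not a number.
Compound 2, `CCc1ccc(-c2ccc(C(=O)Nc3ccc(Oc4ccnc5[nH]ccc45)cc3)nc2)cc1`: in this assay compound 2 gives > 10000 nM, likewise a limit.
Compound 3, `Cc1ccc(-c2ccnc(C(=O)Nc3ccc(Oc4ccnc5[nH]ccc45)cc3)c2)cc1`: in this assay compound 3 gives > 10000 nM, again a limit.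

Compound 3 therefore stands only at a limit, and so do its two companions: all three values sit at the limit of > 10000 nM in this assay, at which 3 of the 3 values shown sit, so none of the three can be placed above or below another. Among the compounds with values here, the single step that joins two measured compounds, a step that the two limits leave unreadable from compound 1 to compound 2, cannot be read for the same reason.

Compound 4, `O=C(Nc1ccc(Oc2ccnc3[nH]ccc23)cc1)c1cc(-c2ccc(Cl)cc2)ccn1`, differs from compound 3 by chloro in place of methyl on an aromatic carbon. Within the data shown here, no measured step bears directly on this change, and the one step that exists is unreadable; the three limits give no sign that a change on that ring brings the readout into the measurable range. The step expected from compound 3 to compound 4 is therefore a step that the limit leaves unreadable from compound 3 to compound 4, none beyond the scatter, with a wide margin of uncertainty. Compound 4 is expected to give 15000 nM in this assay, within a range from 3000 nM to 60000 nM, most probably reported once more as a limit.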

Compound 4, half-maximal inhibitory concentration: 25100 nM
For compound 4 the middle estimate is 1.7-fold (0.22 log units) below the measured one; low and high end bracket the measured number.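

In this assay compound 3 gives > 10000 nM, a limit and not a number. Within the data shown here, compound 4 gives 25100 nM, yet no step from compound 3 to compound 4 can be read: the limit of > 10000 nM in this assay, at which 3 of the 4 values shown sit. The compounds shown leave open whether the change from 4-methylphenyl to 4-chlorophenyl alters the readout at all, and in which direction.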